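From acetoxy to hydroxymethyl on the shared core

This account rests on a few compounds, and the source may have more. Where it says the series, first, only, none or still open, it means among the compounds named here.

In a functional assay, with a stated time of 15 min (a higher number here means that more compound is needed for the effect, a lower number that less compound is needed), compound 2 `CC(=O)Oc1ccc(N)c2ccccc12` stands at > 1000000 nM and this is a limit and not a number. Compound 1 `CCC(=O)Nc1ccc(O)c2ccccc12` gives 16000 nM in this assay and compound 3 `Nc1ccc(OCc2ccccc2)c2ccccc12` gives 7000 nM there. Compound 4 `Nc1ccc(CO)c2ccccc12` replaces acetoxy with hydroxymethyl on an aromatic carbon para to an amino group (hydroxymethyl in place of acetoxy on an aromatic carbon). Among the compounds with values here, no measured pair isolates this change, so the expectation rests on compound 1 and compound 3 both returning numbers in this assay. A large step towards a lower number is expected, estimated as an at least 16-fold lower number from compound 2 to compound 4 (1.22 log units; beyond the scatter) in this series. Compound 4 is expected at 60000 nM with an estimated range from 10000 nM to 400000 nM in this assay and a limit remains possible.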

Compound 4, half-maximal effective concentration: 1000000 nM
Compound 4: middle estimate off by 17-fold (1.22 log units), on the low side; measured number outside the range, above it.
By their numbers in this assay, from the lowest: compound 3; then compound 1; then compound 4.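

In this assay compound 4 gives 1000000 nM, so hydroxymethyl at this position returns a number. Compound 2 stands at > 1000000 nM, which is a limit and not a number. The change from acetoxy to hydroxymethyl therefore shows a number no higher from compound 2 to compound 4 (the limit leaves the size open), its size cannot be read, and the limit is what bears on it: the limit of > 1000000 nM in this assay, at which 1 of the 4 values shown sits.

Still open, going by these compounds, is how far the number moves with this change. Also open, on these data alone, is what a carboxylic acid, an amine or a longer chain would give on this aromatic carbon para to an amino group.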